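The source may report more compounds than this note shows. Statements on the series, on what has been measured and on what is new or still open speak of the compounds shown alone.

The study gathers four compounds on a shared core. Compound 1 `CC(=O)c1ccc2[nH]c(-c3ccc(C(F)(F)F)cc3)nc2c1` carries an acetyl group and a trifluoromethyl-substituted phenyl, and compound 2 `CC(=O)c1ccc2c(c1)nc(-c1ccc(C(F)(F)F)cc1)n2C1CCCCC1` adds a cyclohexyl on the aromatic nitrogen. In an ADME assay on BHK-21 cells (Mesocricetus auratus) for cytotoxicity, read by MTT assay (a lower number here means that less compound is tolerated, a higher number that more compound is tolerated), compound 2 gives 33000 nM. Compound 1 reaches only a limit of this assay, > 100000 nM. The change hydrogen in place of cyclohexyl on an aromatic nitrogen therefore produces an at least 3.0-fold higher number from compound 2 to compound 1 (0.48 log units; beyond the scatter). Compound 3 `C/C(=N\NC(N)=O)c1ccc2c(c1)nc(-c1ccoc1)n2C1CCCCC1` and compound 4 `C/C(=N\NC(N)=O)c1ccc2[nH]c(-c3ccoc3)nc2c1` form a second pair; the difference between the core of compound 2 and the core of compound 3 is not broken down here. For compound 3 in this assay the entry reads "not determined" (no result reported), so no result was reported. Compound 4 differs from compound 3 by hydrogen in place of cyclohexyl on an aromatic nitrogen, the same kind of change, now next to the ring atom that bears a furan-3-yl group rather than a large group. Resting on an at least 3.0-fold higher number from compound 2 to compound 1 (0.48 log units; beyond the scatter), compound 4 is expected to give about 120000 nM, estimated between 40000 nM and 400000 nM. That the earlier step ended at the limit of > 100000 nM in this assay, at which 1 of the 3 values shown sits, suggests compound 4 may likewise be reported only as a limit.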

Compound 4, half-maximal cytotoxic concentration: > 100000 nM
Compound 4 gave a limit, no number (the forecaster's own chance of this, stated with the estimate: 65%); the middle value lies beyond the limit too.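

In this assay compound 4 gives > 100000 nM, which is a limit. Among these compounds, compound 3 has no reported result, so no step to compound 4 can be read. The compounds shown leave open whether hydrogen in place of cyclohexyl changes the number when a furan-3-yl group is present.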